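The source may hold more compounds than are shown below. What is called first, only, known or untested is meant among the compounds shown, and "the series" means these compounds.

Values so far in an ADME assay on microsomes from liver (Rattus norvegicus, strain Sprague-Dawley) for metabolic stability, read by HPLC, using NADPH, with stated times of 5 min and 60 min, tested at 10 uM; on this read-out higher numbers stand for fast clearance and lower numbers for slow clearance:
- compound 1 `CS(=O)(=O)Nc1ccc(CNC(=O)c2ccc(C34CC(C3)C4)cc2)c(Cl)c1` gives 17 mL.min-1.g-1
- compound 2 `COc1ccc(C(=O)NCc2ccc(NS(C)(=O)=O)cc2Cl)cc1` gives 5 mL.min-1.g-1
- compound 3 `CS(=O)(=O)Nc1ccc(CNC(=O)c2ccc(N3CCCCC3)cc2)c(Cl)c1` gives 20 mL.min-1.g-1

Compound 3 stands level with compound 1 (a 1.2-fold higher number from compound 1 to compound 3 (0.07 log units; within the scatter)) and clear of compound 2 (a 4.0-fold higher number from compound 2 to compound 3 (0.60 log units; beyond the scatter)). The next compound, compound 4 `CC(C)(O)c1ccc(C(=O)NCc2ccc(NS(C)(=O)=O)cc2Cl)cc1`, has 1-hydroxy-1-methylethyl in place of piperidin-1-yl on an aromatic carbon.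

Three measured steps change this same place. Within the data shown here, the closest precedent is the swap between piperidin-1-yl and methoxy, a modest step (a 4.0-fold higher number from compound 2 to compound 3 (0.60 log units; beyond the scatter)). Replacing the group of compound 1 with methoxy gives a similar step (a 3.4-fold lower number from compound 1 to compound 2 (0.53 log units; beyond the scatter)). In these three compounds, the two with a ring at this place sit together and the one without sits lower. Among the measured compounds shown here, compound 4 also has no ring there, but no measured compound carries its hydroxy-bearing group, so the range stays wide.

A modest downward step beyond the scatter is expected (a 3.3-fold lower number from compound 3 to compound 4 (0.52 log units; beyond the scatter)). Compound 4 is estimated at 6 mL.min-1.g-1 (expected range 2.5 mL.min-1.g-1 to 14 mL.min-1.g-1).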

Compound 4, intrinsic clearance in microsomes: 1.5 mL.min-1.g-1
The estimate for compound 4 lay 4.0-fold (0.60 log units) above the measured number; the whole stated range lies above it.
By their numbers in this assay, from the lowest: compound 4; then compound 2; then compounds 1 and 3 (each within the scatter of the next).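

In this assay, 1-hydroxy-1-methylethyl gives the lowest number of the four groups at this place on the aromatic ring. The steps to it from the two ring-bearing groups are large (a 13-fold lower number from compound 3 to compound 4 (1.12 log units; beyond the scatter); an 11-fold lower number from compound 1 to compound 4 (1.05 log units; beyond the scatter)), and the step from methoxy is modest but still beyond the scatter (a 3.3-fold lower number from compound 2 to compound 4 (0.52 log units; beyond the scatter)). The two groups without a ring therefore also differ from each other, so the absence of a ring does not alone set the number, and nothing available here accounts for the difference.

As far as these compounds go, it remains open whether the hydroxy or the branched carbon carries the shift, which a tert-butyl group at the same place would help separate. A carboxylic acid or a primary amine there would show how far the number follows the group's hydrogen-bond donor.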